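A few compounds are considered here, and "the series" means these few. Any claim that something is new, unique, unknown or untested is made for them only; others in the source may bear on it.

For the measured compounds named here, in a functional assay (trachea) with Cavia porcellus as the target (on this read-out higher numbers stand for an effect only at larger amounts of compound and lower numbers for an effect already at smaller amounts), compound 1 (`CCCn1c(=O)n(CCN(C)C)c(=O)c2[nH]cnc21`) gives 2700 nM while compound 2 (`CCCn1c(=O)n(CCOC)c(=O)c2[nH]cnc21`) gives 700 nM and so holds the lower of the two numbers measured so far. Compound 3 (`CCCn1c(=O)n(CCC(C)=O)c(=O)c2[nH]cnc21`) is the next to be read, and it departs from compound 2 as follows: acetyl in place of methoxy on a saturated chain carbon, two bonds along the chain from an aromatic nitrogen with acetyl in place of methoxy on a saturated chain carbon, two bonds along the chain from an aromatic nitrogen. Going by the values given here, only one measured step touches that chain carbon: a 3.9-fold lower number from compound 1 to compound 2 (0.59 log units; beyond the scatter) on going from dimethylamino to methoxy. That modest step involves a different leaving group and no acetyl, so it offers only loose guidance. No change beyond the usual scatter is therefore expected in this assay, in either direction. The expected step is a 1.3-fold higher number from compound 2 to compound 3 (0.11 log units; within the scatter) as a rough estimate. For compound 3 the estimated value is 900 nM with an expected range from 300 nM to 2700 nM in this assay.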

Compound 3, half-maximal effective concentration: 3500 nM
For compound 3 the middle estimate is 3.9-fold (0.59 log units) below the measured one; the measured number lies above the stated range.
By their numbers in this assay, from the lowest: compound 2; then compounds 1 and 3 (each within the scatter of the next).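

In this assay, the saturated chain carbon two bonds along the chain from an aromatic nitrogen proves sensitive to a small exchange: putting acetyl in place of methoxy gives a clear change (a 5.0-fold higher number from compound 2 to compound 3 (0.70 log units; beyond the scatter)). Acetyl and dimethylamino, in contrast, are not told apart at this place (a 1.3-fold higher number from compound 1 to compound 3 (0.11 log units; within the scatter)), so among the three groups shown, only methoxy goes with the lower number. Nothing available explains this result.

As far as these compounds go, it remains open whether the lower number is specific to methoxy or would also appear with a hydroxyl, an ethoxy group or a longer chain ending in methoxy. From the compounds shown here alone, how a carboxylic acid or a primary amine would read at this place, and whether the propyl chain on the shared core influences these steps, also remains open.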